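A few compounds are considered here, and "the series" means these few. Any claim that something is new, unique, unknown or untested is made for them only; others in the source may bear on it.

The study concerns inhibition measured in an assay on cells for inhibition of HSP60/HSP10 (Homo sapiens), with a stated time of 60 min; on this read-out higher numbers stand for weaker inhibition and lower numbers for stronger inhibition. Of the compounds shown here, three have been measured. Compound 1, with structure `N#Cc1ccc(S(=O)(=O)Nc2ccc(-c3nc4cc(NS(=O)(=O)c5ccc(C#N)cc5)ccc4o3)cc2)cc1`, gives 49000 nM in this assay. Compound 2, with structure `O=S(=O)(Nc1ccc(-c2nc3ccccc3o2)cc1)c1cccc(Cl)c1`, gives 54000 nM in this assay. Compound 3, with structure `O=S(=O)(Nc1ccc2oc(-c3ccccc3)nc2c1)c1ccc(Cl)c(C(F)(F)F)c1`, gives only a limit in this assay, namely > 100000 nM; this is the limit described as the limit of > 100000 nM in this assay, at which 1 of the 3 values shown sits. Of the two numbers, compound 2 and compound 1 sit within the usual scatter of each other, so no order between them can be claimed, and compound 3 gives no number to compare.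

The step followed here goes from compound 2 to compound 4, whose structure is `C=Cc1ccc(S(=O)(=O)Nc2ccc(-c3nc4ccccc4o3)cc2)cc1` and which has not yet been measured. The change is 4-vinylphenyl in place of 3-chlorophenyl on a sulfonyl sulfur. Going by the values given here, no measured pair among the three compounds shows a step of this kind, so nothing among them fixes its size or direction. Given that compound 2 gives 54000 nM and that both numbers shown sit close to one another, the expected step of a 1.1-fold lower number from compound 2 to compound 4 (0.03 log units; within the scatter) is none beyond the scatter. Compound 4 is therefore expected to give about 50000 nM in this assay, with a range from 15000 nM to 150000 nM.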

Compound 4, half-maximal inhibitory concentration: > 100000 nM
Compound 4: only a limit was reported (the forecaster's own chance of this, stated with the estimate: 25%); middle value at least 2.0-fold (0.30 log units) from the limit.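

In this assay, going by these compounds alone, the change to 4-vinylphenyl in place of 3-chlorophenyl on a sulfonyl sulfur gives the only measured step at this position, an at least 1.8-fold higher number from compound 2 to compound 4 (0.26 log units; that floor lies within the scatter); this figure is a floor, and that floor lies within the scatter, so it does not by itself establish a loss of inhibition. Compound 4 gives > 100000 nM, which is a limit of the assay and not a number. What this pair adds is that a change confined to this one position, with the rest of the structure held constant, can take a compound from a measured number to a limit, and that limit is no longer seen with compound 3 alone: the limit of > 100000 nM in this assay, at which 2 of the 4 values shown sit.

From the compounds shown here alone, how far the true value of compound 4 lies past the limit remains unknown, so the real size of the step stays open. The compounds shown also do not tell whether the loss of the chlorine or the arrival of the vinyl group governs the result, or how a 4-aminophenyl or 4-carboxyphenyl group would behave on the same sulfonyl sulfur.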